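Aryl change from compound 2 to compound 4

This account rests on a few compounds, and the source may have more. Where it says the series, first, only, none or still open, it means among the compounds named here.

Among the compounds with values here, in a functional assay on HL-60 cells (Homo sapiens) for antiproliferative activity, read by MTT assay, with a stated time of 72 h (on this read-out lower numbers stand for stronger inhibition and higher numbers for weaker inhibition), compound 2 `NC1=NC2(CCSCC2)N(OCCCOc2cccc(Cl)c2)C(N)=N1` gives 260 nM, the lowest of the three numbers so far and beyond the scatter of both others. Compound 1 `COc1ccc(OCCCON2C(N)=NC(N)=NC23CCOCC3)cc1` gives 1670 nM and compound 3 `NC1=NC2(CCOCC2)N(OCCCOc2ccc(F)cc2)C(N)=N1` gives 2380 nM.

Compound 4 `NC1=NC2(CCSCC2)N(OCCCOc2cc(Cl)c(Cl)cc2Cl)C(N)=N1` keeps the core of compound 2 and differs at the aromatic end: 2,4,5-trichlorophenyl in place of 3-chlorophenyl on an oxygen on a saturated carbon, (2,4,5-trichlorophenyl in place of 3-chlorophenyl on an oxygen on a saturated carbon).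

Within the data shown here, one measured step bears on this, and only indirectly. It is a 1.4-fold higher number from compound 1 to compound 3 (0.15 log units; within the scatter), a change on the aromatic ring that stayed within the scatter. Among the measured compounds shown here, that step belongs to another core and involves other groups, and no measured step shows a change of chlorine substitution, so the basis is thin. No clear shift in this assay is therefore expected, with at most a slight drift to a lower number.

The expected change is a 1.3-fold lower number from compound 2 to compound 4 (0.11 log units; within the scatter), an estimate that lies within the scatter. For compound 4 the expected value is 200 nM, with an estimated range from 60 nM to 650 nM.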

Compound 4, half-maximal inhibitory concentration: 730 nM
For compound 4 the middle estimate is 3.7-fold (0.56 log units) below the measured one, and the stated range ends below it.
By their numbers in this assay, from the lowest: compound 2; then compound 4; then compounds 1 and 3 (each within the scatter of the next).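

With the core of compound 2 held fixed, replacing 3-chlorophenyl with 2,4,5-trichlorophenyl gives a 2.8-fold higher number from compound 2 to compound 4 (0.45 log units; beyond the scatter) in this assay, so this aromatic end does respond to a change, and here the added chlorines do not bring a lower number. Within the data shown here, the only earlier step on an aromatic ring, a 1.4-fold higher number from compound 1 to compound 3 (0.15 log units; within the scatter) on another core and with other groups, did not show this. No measured evidence accounts for the size or direction of the new step.

With only these two aromatic ends on this core, the compounds shown cannot separate the number of chlorines from where they sit. From the compounds shown here alone, how an unsubstituted phenyl, or an aromatic end carrying an amine or a carboxylic acid, would read on this core also stays open.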